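This account rests on a few compounds, and the source may have more. Where it says the series, first, only, none or still open, it means among the compounds named here.

Measured in a functional assay on HeLa cells (Homo sapiens) for antiproliferative activity, read by resazurin assay; on this read-out lower numbers stand for stronger inhibition and higher numbers for weaker inhibition:
Compound 1 `CCSC(=S)SCC(=O)c1ccccc1`: 5010 nM
Compound 2 `CCSC(=S)SCC(=O)c1ccccc1OC`: 15800 nM
Compound 3 `CCSC(=S)SCC(=O)c1ccc(NS(C)(=O)=O)cc1`: 39800 nM

Compound 1, at 5010 nM, holds the lowest of these three numbers in this assay. The next compound to be tested, compound 4 `CCSC(=S)SC(C)C(=O)c1ccccc1`, carries methyl in place of hydrogen on a saturated chain carbon bound to a carbonyl carbon and a sulfur. Going by the values given here, two measured steps bear on this: a 3.2-fold higher number from compound 1 to compound 2 (0.50 log units; beyond the scatter) and a 7.9-fold higher number from compound 1 to compound 3 (0.90 log units; beyond the scatter). Both are modest and both lead to a higher number. Each of them, however, replaces hydrogen on an aromatic carbon, so neither tests the chain carbon directly. They give only a weak hint that additions to this core do not lower the number. A small rise, or no step beyond the scatter, is therefore expected. The estimate is a 1.6-fold higher number from compound 1 to compound 4 (0.20 log units; within the scatter). For compound 4 the expected value is 8000 nM, within an estimated range of 3000 nM to 25000 nM.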

Compound 4, half-maximal inhibitory concentration: 5010 nM
For compound 4 the middle estimate is 1.6-fold (0.20 log units) above the measured one; the range from low to high includes it.
By their numbers in this assay, from the lowest: compounds 1 and 4 (each within the scatter of the next); then compound 2; then compound 3.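

In this assay, methyl in place of hydrogen on a saturated chain carbon bound to a carbonyl carbon and a sulfur gives no change at the digits printed from compound 1 to compound 4 (within the scatter). Going by these compounds alone, compound 2 and compound 3 each changed an aromatic carbon, so this is the first look at the chain carbon, and it shows that this position takes an added methyl with no shift beyond the scatter. Not every addition to the core of compound 1 therefore raises the number, though no evidence is available to explain this result.

From the compounds shown here alone, one methyl is a single probe of this position, so it remains open whether an ethyl group, a longer chain, an amine or a carboxylic acid on the same carbon would also leave the number unchanged. Going by these compounds, it is also open whether any group there could lower the number.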